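The source may report more compounds than this note shows. Statements on the series, on what has been measured and on what is new or still open speak of the compounds shown alone.

Compound 1 `CC(=O)Nc1ccc(S(=O)(=O)NNC(=O)c2cccnc2Nc2ccc(Cl)cc2)cc1` and compound 2 `O=C(NNS(=O)(=O)c1ccc(F)cc1)c1cccnc1Nc1ccc(Cl)cc1Cl` share one core and were both tested in a functional assay on HCT-15 cells (Homo sapiens) for antiproliferative activity; a higher number here means a weaker inhibitor of growth, a lower number a stronger inhibitor of growth. For compound 1 the reported value > 100000 nM is a limit of the assay, not a number. For compound 2 the reported value > 83100 nM is also a limit. Compound 1 therefore stands at the edge of what was measurable, as described by the limit of > 100000 nM in this assay, at which 1 of the 2 values shown sits, and compound 2 stands at its own edge, described by the limit of > 83100 nM in this assay, at which 1 of the 2 values shown sits. Neither measured compound gave a concentration that could be pinned down.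

Compound 3 `O=C(NNS(=O)(=O)c1ccc(Cl)cc1Cl)c1cccnc1Nc1ccc(Cl)cc1` has not yet been measured in this assay. It differs from compound 1 in one place: 2,4-dichlorophenyl in place of 4-acetamidophenyl on a sulfonyl sulfur. Among the compounds with values here, no step between two measured compounds exists that would show what such a change does here. Because compound 1 only reached a limit with > 100000 nM, and because compound 2 likewise stopped at a limit with > 83100 nM, the expected step of a number no higher from compound 1 to compound 3 (the limit leaves the size open) is none beyond the usual scatter. Compound 3 is accordingly estimated at 100000 nM, within a range from 20000 nM to 300000 nM, most likely again reported as a limit.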

Compound 3, concentration for total growth inhibition: > 100000 nM
Compound 3 gave a limit, no number; the forecaster's own chance of this, stated with the estimate: 70%; the middle value sits exactly at the limit.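

In this assay compound 3 gave only a limit (> 100000 nM), not a number. Within the data shown here, compound 1 also stopped at a limit, so no step between compound 1 and compound 3 can be read. The compounds shown leave open how strongly any of them inhibits growth, and whether swapping 4-acetamidophenyl for 2,4-dichlorophenyl changes it at all.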